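The source may report more compounds than this note shows. Statements on the series, on what has been measured and on what is new or still open speak of the compounds shown alone.

For the measured compounds named here, compound 1 `COc1ccc(-c2cnc3nc(N)nc(N4CCN(C(=O)NCc5ccc(F)cc5)CC4)c3n2)cc1OC` gives 37 nM in a functional assay on cells (T-cell, Homo sapiens) for inhibition (on this read-out lower numbers stand for stronger inhibition and higher numbers for weaker inhibition), and among the three measured compounds it carries the only number reported. Compound 2 `COc1ccc(-c2cnc3nc(N)nc(OC(C)C)c3n2)cc1` gives only a limit in this assay, namely > 10000 nM. Compound 3 `CCOc1nc(N)nc2ncc(-c3ccc(Cl)c(Cl)c3)nc12` likewise gives only a limit, > 10000 nM. Going by the values given here, compound 1 therefore stands alone as the single measured value, the other two sitting at the limit of > 10000 nM in this assay, at which 2 of the 3 values shown sit. Compound 4 `COc1ccc(-c2cnc3nc(N)nc(N4CCN(C(=O)CCc5ccccc5)CC4)c3n2)cc1OC` is not yet measured. It differs from compound 1 in one place: phenethyl in place of (4-fluorobenzyl)amino on a carbonyl carbon. Among the compounds with values here, no step between two measured compounds is available, so the expectation rests on the structural change alone. The step of a 2.7-fold higher number from compound 1 to compound 4 (0.43 log units; beyond the scatter) is expected to be a modest weakening, somewhat beyond the scatter. Compound 4 is accordingly estimated at 100 nM, within 30 nM to 400 nM.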

Compound 4, half-maximal inhibitory concentration: 100 nM
For compound 4 middle estimate and measured number coincide at the digits printed; measured number inside the range.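

In this assay the change on the carbonyl carbon costs only a modest amount, a 2.7-fold higher number from compound 1 to compound 4 (0.43 log units; beyond the scatter), so the (4-fluorobenzyl)amino group is not indispensable at this position. Phenethyl keeps compound 4 in measurable range, even though the nitrogen with its hydrogen-bond donor and the fluorine both leave in this one change. No measurement shown bears on the cause of this step.

On these data alone, how the step divides between the fluorine and the nitrogen remains open. So does the reading of a carboxylic acid or a longer chain, such as phenylpropyl, on this carbonyl carbon.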